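This account rests on a few compounds, and the source may have more. Where it says the series, first, only, none or still open, it means among the compounds named here.

Three close relatives share one core and were compared in a functional assay on A549 cells (Homo sapiens) for antiproliferative activity, read by MTT assay, with a stated time of 48 h; on this read-out higher numbers stand for weaker inhibition and lower numbers for stronger inhibition. Compound 1 `COc1ccc(N/C=C\C(=O)c2cn(-c3ccccc3)nc2-c2ccc(Cl)cc2)cc1` gives 6460 nM in this assay. Compound 2 `COc1ccc(-c2nn(-c3ccccc3)cc2C(=O)/C=C\Nc2ccc(F)cc2)cc1` gives 3980 nM. Compound 3 `COc1ccc(-c2nn(-c3ccccc3)cc2C(=O)/C=C\Nc2ccc(Cl)cc2)cc1` gives 2970 nM, the lowest of the three numbers; the gap to compound 2 stays within the scatter, while the gap to compound 1 lies beyond it. Among the measured compounds shown here, the only step between two compounds that differ in a single place, a 1.3-fold lower number from compound 2 to compound 3 (0.13 log units; within the scatter), is within the scatter.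

Compound 4 `COc1ccc(N/C=C\C(=O)c2cn(-c3ccccc3)nc2-c2ccc(OC)cc2)cc1` differs from compound 3 by methoxy in place of chloro on an aromatic carbon. For the measured compounds named here, only the step from compound 2 to compound 3 touches the same place, and it was within the scatter; it swaps one halogen for another rather than for a methoxy, so it bears on the present change only loosely. Compound 1 carries a methoxy at that place, but it also differs from compound 3 elsewhere, so its value cannot isolate the change. A step of a 1.2-fold higher number from compound 3 to compound 4 (0.08 log units; within the scatter) is therefore expected in this assay, small and with no clear direction beyond the scatter. Compound 4 is estimated at 3600 nM in this assay, with a range from 1500 nM to 8500 nM.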

Compound 4, half-maximal inhibitory concentration: 6780 nM
Compound 4: middle estimate off by 1.9-fold (0.27 log units), on the low side, within the range that was stated.
By their numbers in this assay, from the lowest: compounds 3, 2, 1 and 4 (each within the scatter of the next, the first and the last beyond it).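

In this assay, among the compounds shown here, exchanging chloro for methoxy on the ring of the (4-chlorophenyl)amino group gives a 2.3-fold higher number from compound 3 to compound 4 (0.36 log units; beyond the scatter), the first single-place change to pass beyond the scatter, so a substituent at this position can shift the number measurably. The result is limited, however: replacing fluoro with methoxy at the same place gives a 1.7-fold higher number from compound 2 to compound 4 (0.23 log units; within the scatter), which stays within the scatter, so only the comparison with chloro clearly separates methoxy from a halogen here. The same exchange of chloro for methoxy on the other ring, 4-chlorophenyl to 4-methoxyphenyl, gives a 1.0-fold higher number from compound 1 to compound 4 (0.02 log units; within the scatter), also within the scatter, so in these compounds the effect of this swap depends on which ring carries it.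

Nothing available here explains why the two rings differ in this way. As far as these compounds go, it also remains open how a hydrogen, a hydroxyl, an amine or a trifluoromethyl group would compare at the position para to a large group on either ring, and whether the number would follow the same order with those groups in place.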